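The source may hold more compounds than are shown below. What is called first, only, known or untested is meant among the compounds shown, and "the series" means these compounds.

Measured compounds:
- compound 2, `Cc1ccccc1-n1cc(-c2cccc(NS(=O)(=O)c3c[nH]c(=O)[nH]c3=O)c2)nn1`: 9570 nM in a functional assay on HepG2 cells (Homo sapiens) for antiproliferative activity, read by MTT assay, with a stated time of 24 h; a lower number here means a stronger inhibitor, a higher number a weaker inhibitor
- compound 1, `O=c1[nH]cc(S(=O)(=O)Nc2ccccc2-c2cn(-c3ccc(F)cc3)nn2)c(=O)[nH]1`: > 20000 nM in this assay, which is a limit of the assay and not a number

Among the measured compounds shown here, compound 2 holds the only numerical value in this assay; the other entry, for compound 1, is the limit of > 20000 nM in this assay, at which 1 of the 2 values shown sits. For the measured compounds named here, with one number and one limit, no measured step exists, and compound 1 and compound 2 differ in more than one place, so their two values show only that compound 2 reads as a number where compound 1 does not.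

Compound 3, `O=c1[nH]cc(S(=O)(=O)Nc2cccc(-c3cn(-c4ccc(Cl)cc4)nn3)c2)c(=O)[nH]1`, is the next compound to be measured. It differs from compound 2 by 4-chlorophenyl in place of 2-methylphenyl on an aromatic nitrogen. Going by the values given here, no measured step covers this kind of exchange, so the size of the change is open; a small shift of roughly the scatter, if any, is expected, leaning weaker. The estimate for compound 3 in this assay is 12000 nM, with a range from 4000 nM to 40000 nM, meaning an expected step of a 1.3-fold higher number from compound 2 to compound 3 (0.10 log units; within the scatter) from compound 2.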

Compound 3, half-maximal inhibitory concentration: 1960 nM
Compound 3: the middle estimate sits 6.1-fold (0.79 log units) above what was measured; the whole stated range lies above it.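

On the aromatic nitrogen of the five-membered aromatic ring with 3 nitrogen, replacing 2-methylphenyl with 4-chlorophenyl gives the series its first readable step in this assay: a 4.9-fold lower number from compound 2 to compound 3 (0.69 log units; beyond the scatter). The step lies beyond the scatter, so the read-out responds to the aryl group at this position even though both groups hold 7 heavy atoms and neither carries a hydrogen-bond donor or acceptor. No measurement shown bears on why the number falls with this exchange.

The exchange changes both the substituent and where it sits on the phenyl ring, so the chlorine and its placement cannot be separated on this one step. From the compounds shown here alone, how 2-chlorophenyl, 4-methylphenyl, or a phenyl ring carrying an amine or a carboxylic acid would read at this nitrogen remains open.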